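A few compounds are considered here, and "the series" means these few. Any claim that something is new, unique, unknown or untested is made for them only; others in the source may bear on it.

Of the compounds shown here, three have so far been measured in a functional assay on HeLa cells (Homo sapiens) for cytotoxicity, read by MTT assay, with a stated time of 72 h, tested at 10 uM; a higher number here means more inhibition of growth at the concentration tested, a lower number less inhibition of growth. Compound 1 `N/C(=N\NC(=S)N1CCCCCC1)c1ccccn1` gives 67.4%. Compound 2 `Cc1ccnc(/C(N)=N/NC(=S)N2CCCCCC2)c1` gives 55.8%. Compound 3 `Cc1cccc(/C(N)=N/NC(=S)N2CCCC2)n1` gives 79.2%, the highest of the three, with its steps to both others beyond the scatter. The difference between the cores of compound 3 and compound 2 is not broken down here. Compound 2 and compound 1 differ in one place, (hydrogen in place of methyl on an aromatic carbon), and that change gave a number 11.6 percentage points higher from compound 2 to compound 1 (beyond the scatter). Compound 4 `N/C(=N\NC(=S)N1CCCC1)c1ccccn1`, not yet measured, differs from compound 3 by the same kind of change, (hydrogen in place of methyl on an aromatic carbon); here the methyl sits next to the ring nitrogen and meta to a large group, whereas in compound 2 it sits meta to a large group and opposite the ring nitrogen. Resting on the earlier step of a number 11.6 percentage points higher from compound 2 to compound 1 (beyond the scatter), the step expected here is a number 2.8 percentage points higher from compound 3 to compound 4 (within the scatter). Compound 4 is expected to give 82%, in a range from 66% to 93%.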

Compound 4, percent growth inhibition at one concentration: 63.5%
For compound 4 the middle estimate is 18.5 percentage points above the measured one; the whole stated range lies above it.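

In this assay, hydrogen in place of methyl on an aromatic carbon gave a number 15.7 percentage points lower from compound 3 to compound 4 (beyond the scatter), so the change did not carry over from one core to the other, even in direction: the same change on two cores in this assay, a number 11.6 percentage points higher (beyond the scatter) from compound 2 to compound 1 and a number 15.7 percentage points lower (beyond the scatter) from compound 3 to compound 4, 27.3 percentage points apart, beyond the scatter of two such steps. In this series, then, a step read on one core is a poor guide to the same change on another. These two pairs do not show why the steps part ways, since they differ both in where the methyl sits and in the rest of the core, and two pairs cannot separate those differences.

On these data alone, it remains open how each core would respond with the methyl moved to the place it holds on the other core. Also open, as far as these compounds go, is whether an ethyl or methoxy group in that place would follow either step.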